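Swapping a hydroxy for an aminoethylamino on a nonyl-chain aminoglycoside

A few compounds are considered here, and "the series" means these few. Any claim that something is new, unique, unknown or untested is made for them only; others in the source may bear on it.

Of the compounds shown here, two have been tested for cytotoxicity in a toxicity assay on the whole organism (J774 cells) for cytotoxicity, with Mus musculus as the target, read by MTT assay, with a stated time of 24 h, tested at 30 uM; on this read-out higher numbers stand for a weaker effect at the one concentration tested and lower numbers for a stronger effect. Compound 1, `CCCCCCCCCO[C@@H]1[C@@H](N)[C@@H](OCC(O)CO)O[C@H](CN)[C@H]1OCCCCCCCCC`, gives 8.8%, the lowest of the two numbers. Compound 2, `NC[C@H]1O[C@H](O[C@H]2[C@H](O)[C@@H](O)[C@H](N)C[C@@H]2N)[C@H](N)[C@@H](OCCCc2ccc3ccccc3c2)[C@@H]1OCCCc1ccc2ccccc2c1`, gives 66.9%, a number far higher than that of compound 1, beyond the usual scatter. Both values are read at one concentration, so they describe the size of the effect there rather than a potency.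

Compound 3, `CCCCCCCCCO[C@@H]1[C@@H](N)[C@@H](OCC(O)CNCCN)O[C@H](CN)[C@H]1OCCCCCCCCC`, is not yet measured. Its difference from compound 1 is (2-aminoethyl)amino in place of hydroxy on a saturated chain carbon, two bonds along the chain from an oxygen on a saturated carbon. The side chain keeps its oxygen and its remaining hydroxy; only its end group changes. Among the compounds with values here, no measured pair in this set shows such a step, so its size is unknown. Compound 3 is expected to stay close to compound 1, with an estimated change in this assay of a number 6.2 percentage points higher from compound 1 to compound 3 (within the scatter), lying within or only just beyond the scatter. The estimated value for compound 3 in this assay is 15%, in a range from 3% to 40%.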

Compound 3, a percentage reported as activity, at one concentration (the size of the read-out at that concentration, not a potency): 53%
Compound 3: middle estimate off by 38 percentage points, on the low side; the whole stated range lies below it.
By their numbers in this assay, from the lowest: compound 1; then compound 3; then compound 2.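

In this assay, putting (2-aminoethyl)amino in place of hydroxy at the end of the side chain gives a number 44.2 percentage points higher from compound 1 to compound 3 (beyond the scatter) and so a much weaker effect at the one concentration tested. The shared core and both nonyl chains stay the same, so this position is not a silent one: a change at this single chain end is enough to move the read-out well beyond the usual scatter. Nothing at hand explains why the effect weakens with this swap.

On these data alone, it remains open whether a simple amine in the same place would move the read-out as far as the full (2-aminoethyl)amino group does. Also open, as far as these compounds go, is what a carboxylic acid at this chain end, or a longer chain carrying the terminal amine, would do.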